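Adding a 3,5-difluorophenyl group to compound 3

A few compounds are considered here, and "the series" means these few. Any claim that something is new, unique, unknown or untested is made for them only; others in the source may bear on it.

Compound 1 `CCCCCCOc1ccc(NC(=O)C2CCCNC2)cc1` gives 43000 nM
Compound 2 `O=C(Nc1cccc(OCc2ccccc2)c1)C1CCCNC1` gives "not determined" (no result reported)
Compound 3 `O=C(Nc1cccc(OCc2ccccc2)c1)C1CCNCC1` gives "not determined" (no result reported)

Among the compounds with values here, compound 3 has no single number in a functional assay on a cell-free system (Platelet, plasma, Homo sapiens) for inhibition (a lower number here means a stronger inhibitor, a higher number a weaker inhibitor), and neither has compound 2, so the only measured anchor is compound 1 (43000 nM). The next structure is compound 4 (`O=C(Nc1cccc(OCc2ccc(-c3cc(F)cc(F)c3)cc2)c1)C1CCNCC1`). The change is 3,5-difluorophenyl in place of hydrogen on an aromatic carbon and it sits on an aromatic carbon of a six-membered aromatic ring of carbon only, para to a large group. Without a number for compound 3, the size of this step in this assay cannot be read directly, but a sizeable move toward stronger inhibition is expected. Compound 4 is expected at 5000 nM (estimated range 600 nM to 40000 nM).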

Compound 4, half-maximal inhibitory concentration: 17000 nM
Compound 4: the middle estimate sits 3.4-fold (0.53 log units) below what was measured, within the range that was stated.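

No new step can be read between compound 3 and compound 4: in this assay only compound 4 has a single number, 17000 nM. No measurement shown here offers an explanation for this result. Going by these compounds, what the 3,5-difluorophenyl group itself adds to inhibition remains open.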